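The compounds below may be only part of what the source reports. "The series", "measured", "known", "first", "only" and "open" are said of these compounds alone.

Measured compounds, in an assay on HT-29 cells for inhibition of Serine-protein kinase ATM (Homo sapiens), read by fluorescence, with a stated time of 1 h; a lower number here means a stronger inhibitor, a higher number a weaker inhibitor:
compound 1 `CCC(CC)CNc1c(C(N)=O)cnc2ccc(-c3cccnc3)cc12` gives 73 nM
compound 2 `NC(=O)c1cnc2ccc(-c3cccnc3)cc2c1NC1CCCC1` gives 137 nM
compound 3 `C[C@H](Nc1c(C(N)=O)cnc2ccc(-c3cccnc3)cc12)C1CCOCC1` gives 168 nM

Compound 1 holds the lowest number of the three; the gap a 1.9-fold higher number from compound 1 to compound 2 (0.27 log units; within the scatter) lies within the scatter, while a 2.3-fold higher number from compound 1 to compound 3 (0.36 log units; beyond the scatter) is a modest step beyond it. The pair compound 2 to compound 3 shows a 1.2-fold higher number from compound 2 to compound 3 (0.09 log units; within the scatter).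

Compound 4 `CCC(CC)CNc1c(C(N)=O)cnc2ccc(-c3ccnnc3)cc12` differs from compound 1 only in the change (pyridazin-4-yl in place of pyridin-3-yl on an aromatic carbon). Among the measured compounds shown here, none of the measured steps touches this position; all three concern the group on the ring nitrogen. For the measured compounds named here, no measured step therefore bears on the change, and no direction can be drawn from the series. A step of a 1.5-fold higher number from compound 1 to compound 4 (0.18 log units; within the scatter) is expected, within or near the scatter. Compound 4 is estimated at 110 nM, range 40 nM to 300 nM.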

Compound 4, half-maximal inhibitory concentration: 908 nM
Estimate against measurement, compound 4: 8.3-fold (0.92 log units) below; measured number outside the range, above it.
By their numbers in this assay, from the lowest: compounds 1, 2 and 3 (each within the scatter of the next, the first and the last beyond it); then compound 4.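

The group on the aromatic carbon of the shared core matters far more than the nitrogen substituents compared so far: in this assay pyridazin-4-yl in place of pyridin-3-yl gives a 12-fold higher number from compound 1 to compound 4 (1.09 log units; beyond the scatter) and exceeds every step among those substituents. The entering ring has the same heavy-atom count as the leaving one but an added ring nitrogen. Nothing available explains the loss.

Going by these compounds, whether phenyl or pyrimidin-5-yl at this carbon would give a similar number remains open. So does whether pyridazin-4-yl costs as much alongside cyclopentyl on the nitrogen.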